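Working notes: aryl swap from compound 3 to compound 4

This account rests on a few compounds, and the source may have more. Where it says the series, first, only, none or still open, it means among the compounds named here.

Measured so far in an ADME assay on PANC-1 cells (Homo sapiens) for inhibition, read by MTT assay; on this read-out higher numbers stand for weaker inhibition of growth and lower numbers for stronger inhibition of growth:
compound 1 `Cc1nc(C)c(-c2nn(-c3ccc(F)cc3)cc2/C=C/C(=O)c2cc(Cl)ccc2O)s1` gives > 250 ug/mL, which is a limit of the assay and not a number.
compound 2 `Cc1nc(C)c(-c2nn(-c3ccc(F)cc3)cc2/C=C/C(=O)c2c(O)cc(C)c(Cl)c2C)s1` gives 35.2 ug/mL.
compound 3 `Cc1nc(C)c(-c2nn(-c3ccc(F)cc3)cc2C2CC(c3cc(Br)ccc3O)=NN2)s1` gives 76.4 ug/mL.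

Among the two numbers, compound 3 has the higher one; the nearest is compound 2, with a number lower by a margin beyond the scatter. Compound 4 `Cc1nc(C)c(-c2nn(-c3ccc(F)cc3)cc2C2CC(c3c(O)cc(C)c(Cl)c3C)=NN2)s1` is the matching unmeasured analogue of compound 3, and the change is 3-chloro-6-hydroxy-2,4-dimethylphenyl in place of 5-bromo-2-hydroxyphenyl on a carbon with a double bond to nitrogen.

Among the measured compounds shown here, the only measured step that bears on this swap is the one on the carbonyl carbon, an at least 7.1-fold lower number from compound 1 to compound 2 (0.85 log units; beyond the scatter), where the same 3-chloro-6-hydroxy-2,4-dimethylphenyl replaced a 5-chloro-2-hydroxyphenyl. That step started from the limit of > 250 ug/mL in this assay, at which 1 of the 3 values shown sits, so its true size is not known beyond the stated minimum. The corresponding change here starts from a 5-bromo-2-hydroxyphenyl rather than a chloro analogue, and sits on a different carbon, so a smaller move is assumed. On that basis a lower number is expected in this assay for compound 4, a step of about a 3.1-fold lower number from compound 3 to compound 4 (0.49 log units; beyond the scatter).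

The estimate for compound 4 is 25 ug/mL, with a likely range from 8 ug/mL to 70 ug/mL.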

Compound 4, concentration for 50% growth inhibition: 41.6 ug/mL
The estimate for compound 4 lay 1.7-fold (0.22 log units) below the measured number, within the range that was stated.
By their numbers in this assay, from the lowest: compounds 2, 4 and 3 (each within the scatter of the next, the first and the last beyond it). At a limit, above all of these: compound 1.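

In this assay, 3-chloro-6-hydroxy-2,4-dimethylphenyl in place of 5-bromo-2-hydroxyphenyl on a carbon with a double bond to nitrogen gives a 1.8-fold lower number from compound 3 to compound 4 (0.26 log units; within the scatter), so at this position the read-out does not separate the two aryl groups. The same entering group on a carbonyl carbon gave an at least 7.1-fold lower number from compound 1 to compound 2 (0.85 log units; beyond the scatter), so a step beyond the scatter at that place is not repeated at this one, although the group leaving there was 5-chloro-2-hydroxyphenyl and not the bromo group that leaves here. The two steps cannot be compared in size because the carbonyl step starts from a value that is not a number: the limit of > 250 ug/mL in this assay, at which 1 of the 4 values shown sits.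

The 5-chloro-2-hydroxyphenyl group appears only on the carbonyl carbon and the 5-bromo-2-hydroxyphenyl group only on the carbon with a double bond to nitrogen, so the shown compounds do not separate the change of halogen from the change of place. Also open, as far as these compounds go, is how a phenyl carrying an amine or a carboxylic acid in place of the hydroxy group would read at this position.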